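A Longer Hydroxyalkyl Arm on the Alkyne

The source may hold more compounds than are shown below. What is called first, only, known or untested is meant among the compounds shown, and "the series" means these compounds.

Compound 1, `NC(=O)c1cc(Cl)c2c(Cl)c(C#CCO)n([C@H]3CCCNC3)c2n1`, is tested in a functional assay on KG-1 cells (Homo sapiens) for antiproliferative activity (on this read-out lower numbers stand for an effect already at smaller amounts and higher numbers for an effect only at larger amounts of compound), where compound 1 gives 301 nM. Two relatives were measured alongside: compound 2, `NC(=O)c1cc(Cl)c2c(Cl)c(C#CC3COCCO3)n([C@H]3CCCNC3)c2n1`, gives 77 nM; 203 nM (2 entries), and compound 3, `NC(=O)c1cc(Cl)c2c(Cl)c(C#CC3CCCO3)n([C@H]3CCCNC3)c2n1`, gives 223 nM; 91 nM (2 entries). Among the three, compound 1 alone rests on a single reading; the repeat entries of the others, the several entries of compound 2 in this assay, 77 nM; 203 nM (2 entries) and (the several entries of compound 3 in this assay, 223 nM; 91 nM (2 entries)), show how widely such readings can spread, so compound 1 cannot be set apart from them. Compound 4, `CC(O)CC#Cc1c(Cl)c2c(Cl)cc(C(N)=O)nc2n1[C@H]1CCCNC1`, differs from compound 1 on a saturated chain carbon bound to a triple-bonded carbon: 1-hydroxyethyl in place of hydroxy on a saturated chain carbon bound to a triple-bonded carbon. Among the measured compounds shown here, no measured pair isolates this change, so the step is expected to stay within the usual scatter, a 1.4-fold lower number from compound 1 to compound 4 (0.14 log units; within the scatter). Compound 4 is therefore expected to give 220 nM, within a range from 80 nM to 600 nM.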

Compound 4, half-maximal effective concentration: 48 nM
For compound 4 the middle estimate is 4.6-fold (0.66 log units) above the measured one; the measured number lies below the stated range.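

Among the compounds shown here, compounds 1 to 3 offered no step that changed one place only; here, a 6.3-fold lower number from compound 1 to compound 4 (0.80 log units; beyond the scatter) in this assay gives the first such step. At this saturated chain carbon, then, 1-hydroxyethyl is accepted in place of hydroxy, and the number falls rather than rises. The step is modest, since repeat readings can spread widely, as with compound 2: the several entries of compound 2 in this assay, 77 nM; 203 nM (2 entries)

As far as these compounds go, whether the hydroxy group itself matters on this longer arm stays open. An amine in its place, or a longer hydroxyalkyl chain, would help to show this.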